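Cyclobutylmethoxy in Place of Methoxyethoxy on a Chloro-Substituted Core

This account rests on a few compounds, and the source may have more. Where it says the series, first, only, none or still open, it means among the compounds named here.

Of the compounds shown here, two have been measured in an assay for inhibition of kynurenine 3-monooxygenase (Homo sapiens), read by mass spectrometry, with a stated time of 1 h; on this read-out lower numbers stand for stronger inhibition and higher numbers for weaker inhibition. Compound 1, `COCCOc1cc2oc(=O)n(CCC(=O)O)c2cc1Cl`, gives 31.6 nM in this assay, the higher of the two numbers. Compound 2, `Cc1ccc([C@@H](C)Oc2cc3onc(CCC(=O)O)c3cc2Cl)nc1`, differs from compound 1 in several places at once. In this assay compound 2 gives 3.16 nM. Among the measured compounds shown here, this lower number lies beyond the usual scatter; since the two structures differ in more than one place, the comparison says only that compound 2 inhibits more strongly.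

Compound 3, `O=C(O)CCn1c(=O)oc2cc(OCC3CCC3)c(Cl)cc21`, is the next compound to be measured in this assay. It differs from compound 1 in one place: cyclobutyl in place of methoxymethyl on a saturated chain carbon bound to an oxygen on an aromatic ring. For the measured compounds named here, no measured pair shows this change on its own, so no step for it is known. Without a measured precedent, the expected step from compound 1 to compound 3 is a small one, a 1.6-fold lower number from compound 1 to compound 3 (0.20 log units; within the scatter), not clearly beyond the scatter in either direction. On that basis compound 3 is estimated to give 20 nM in this assay, with an expected range from 7 nM to 60 nM.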

Compound 3, half-maximal inhibitory concentration: 25.1 nM
Compound 3: middle estimate off by 1.3-fold (0.10 log units), on the low side; the range from low to high includes it.
By their numbers in this assay, from the lowest: compound 2; then compounds 3 and 1 (each within the scatter of the next).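

Among the compounds shown here, compound 3 gives the first reading of a single change at this position: on the shared core, 2-methoxyethoxy gives way to cyclobutylmethoxy, and this assay shows a 1.3-fold lower number from compound 1 to compound 3 (0.10 log units; within the scatter) with the two numbers lying within the usual scatter of each other. The leaving methoxymethyl carries a hydrogen-bond acceptor and no ring, while the entering cyclobutyl carries no hydrogen-bond acceptor and has a four-membered non-aromatic ring of carbon only, so on this core and in this place, the read-out does not separate these two groups. No supporting evidence is available to explain this result.

The compounds shown leave open whether an amine or a longer chain on the same saturated chain carbon would move the number beyond the scatter, since this single pair shows only one replacement of methoxymethyl. For the compounds shown here, they also leave open whether cyclobutyl in place of methoxymethyl would give a similar result on another core, as the one step available comes from the core of compound 1 alone.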